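Adding a Nitrile to the Core of Compound 1

The source may report more compounds than this note shows. Statements on the series, on what has been measured and on what is new or still open speak of the compounds shown alone.

Compound 1 `C=CC(=O)Nc1cc(Nc2nccc(-c3cn(C)c4ccc(F)cc34)n2)c(OC)cc1N(C)CCN(C)C` is the starting point here. Going by the values given here, in a functional assay on A549 cells (Homo sapiens) for antiproliferative activity, read by MTT assay, with a stated time of 72 h (on this read-out lower numbers stand for stronger inhibition and higher numbers for weaker inhibition), compound 1 gives 329 nM, the lowest of the two numbers so far. Among the compounds with values here, its only measured neighbour is compound 2 `CCC/C=C\C(=O)Nc1cc(Nc2nccc(-c3cn(C)c4ccc(F)cc34)n2)c(OC)cc1N(C)CCN(C)C`, which in this assay gives 1030 nM; the step of a 3.1-fold higher number from compound 1 to compound 2 (0.50 log units; beyond the scatter) comes from a longer chain on the carbonyl carbon of the amide, a different part of the molecule.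

Compound 3 `C=CC(=O)Nc1cc(Nc2ncc(C#N)c(-c3cn(C)c4ccc(F)cc34)n2)c(OC)cc1N(C)CCN(C)C` differs from compound 1 in one place: cyano in place of hydrogen on an aromatic carbon, on an aromatic carbon of the shared core, ortho to a 5-fluoro-1-methyl-1H-indol-3-yl group and two atoms from the ring nitrogen. Within the data shown here, no measured step touches this position, so the one step available is no guide to it. Without such a guide, the expected step of a 1.1-fold lower number from compound 1 to compound 3 (0.04 log units; within the scatter) is none beyond the scatter. Compound 3 is therefore estimated at 300 nM in this assay, with a range from 90 nM to 1000 nM.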

Compound 3, half-maximal inhibitory concentration: 9700 nM
Compound 3: middle estimate off by 32-fold (1.51 log units), on the low side, outside the stated range (above it).
By their numbers in this assay, from the lowest: compound 1; then compound 2; then compound 3.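

In this assay, cyano in place of hydrogen on this aromatic carbon gives a 29-fold higher number from compound 1 to compound 3 (1.47 log units; beyond the scatter) and so moves compound 3 to much weaker inhibition. The earlier step concerned the chain on the amide carbonyl, whereas this one shows that the shared core is also sensitive to change: an entering group of only 2 heavy atoms produces a large step, and among the two groups shown at this carbon, hydrogen gives the stronger inhibition. No measurement available here explains why the number rises so sharply.

The compounds shown have only hydrogen and cyano at this carbon, so it remains open how a methyl, a chlorine or an amine there would read out. Going by these compounds, it also remains open whether the cyano step would keep its size with the pent-1-en-1-yl chain of compound 2 on the carbonyl carbon.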